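The source may report more compounds than this note shows. Statements on the series, on what has been measured and on what is new or still open speak of the compounds shown alone.

In a functional assay on Hep 3B2 cells (Homo sapiens) for cytotoxicity, read by MTT assay, with a stated time of 6 days (on this read-out higher numbers stand for weaker inhibition and lower numbers for stronger inhibition), compound 1 (`O=C1COc2ccc(F)cc2N1Cc1cn(Cc2ccccc2)nn1`) gives > 100000 nM, which is a limit and not a number. Compound 2 (`CCC1Oc2ccccc2N(Cc2cn(Cc3ccccc3)nn2)C1=O`) likewise gives only a limit, > 100000 nM. Going by the values given here, compound 3 (`CCCC1Oc2ccccc2N(Cc2cn(Cc3ccccc3)nn2)C1=O`) gives 61800 nM, the only true number so far. The data are dominated by the limit of > 100000 nM in this assay, at which 2 of the 3 values shown sit. Compound 4 (`O=C1C(c2ccccc2)Oc2ccccc2N1Cc1cn(Cc2ccccc2)nn1`) differs from compound 3 in one place: phenyl in place of propyl on a saturated ring carbon. Among the compounds with values here, the sole measured step, an at least 1.6-fold lower number from compound 2 to compound 3 (0.20 log units; that floor lies within the scatter), is a small chain extension and does not involve a ring, so it offers little guidance. No change beyond the scatter is therefore expected in this assay. The expected change is a 1.2-fold lower number from compound 3 to compound 4 (0.09 log units; within the scatter). For compound 4, the estimated value is 50000 nM, within an expected range of 18000 nM to 100000 nM.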

Compound 4, half-maximal inhibitory concentration: > 100000 nM
Compound 4: a limit, no number (the forecaster's own chance of this, stated with the estimate: 35%); at least 2.0-fold (0.30 log units) between middle value and limit.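

In this assay, phenyl in place of propyl on the saturated ring carbon next to the ring oxygen gives an at least 1.6-fold higher number from compound 3 to compound 4 (0.20 log units; that floor lies within the scatter), so this aromatic ring brings no measurable gain over the chain, though that floor is too small to call the change a loss. The step between the ethyl and phenyl compounds cannot be read, as both values are limits. Few values here are true numbers: the limit of > 100000 nM in this assay, at which 3 of the 4 values shown sit.

Still open, from the compounds shown here alone, is whether a butyl chain or an amine on this carbon would give a lower number than compound 3, at 61800 nM.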